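Phenyl to 2-methylprop-1-en-1-yl on the shared core

The source may hold more compounds than are shown below. What is called first, only, known or untested is meant among the compounds shown, and "the series" means these compounds.

Compound 1 `CC(C)c1sc(-c2ccccc2)c(-c2cccc(C(F)(F)F)c2)c1/C=C/[C@@H](O)C[C@@H](O)CC(=O)O` gives 2980 nM in an assay on microsomes for inhibition of 3-hydroxy-3-methylglutaryl-coenzyme A reductase (Rattus norvegicus); a higher number here means a weaker inhibitor, a lower number a stronger inhibitor. Compound 2 `CC(C)c1sc(-c2ccccc2)c(-c2cccc(F)c2)c1/C=C/[C@@H](O)C[C@@H](O)CC(=O)O` gives 49 nM in this assay, a change of a 61-fold lower number from compound 1 to compound 2 (1.78 log units; beyond the scatter). Compound 3 `CC(C)c1sc(-c2ccccc2)c(-c2ccc(F)cc2)c1/C=C/[C@@H](O)C[C@@H](O)CC(=O)O` gives 4.4 nM, with a 680-fold lower number from compound 1 to compound 3 (2.83 log units; beyond the scatter) and an 11-fold lower number from compound 2 to compound 3 (1.05 log units; beyond the scatter); compound 3 thus holds the lowest number of the three, beyond the scatter from both others. Compound 4 `CC(C)=Cc1sc(C(C)C)c(/C=C/[C@@H](O)C[C@@H](O)CC(=O)O)c1-c1ccc(F)cc1` differs from compound 3 by 2-methylprop-1-en-1-yl in place of phenyl on an aromatic carbon. None of the three measured steps bears on this change: all of them alter the fluorinated phenyl group and leave the phenyl untouched, so their size gives no guide here. Without a measured precedent, the expected step is a 2.7-fold higher number from compound 3 to compound 4 (0.44 log units; beyond the scatter), a moderate rise in the number. Compound 4 is therefore estimated at 12 nM, within 3 nM to 50 nM.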

Compound 4, half-maximal inhibitory concentration: 15 nM
The estimate for compound 4 lay 1.3-fold (0.10 log units) below the measured number; the measured number falls inside the stated range.
By their numbers in this assay, from the lowest: compound 3; then compound 4; then compound 2; then compound 1.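

At the aromatic carbon next to the ring sulfur, the step in this assay is a 3.4-fold higher number from compound 3 to compound 4 (0.53 log units; beyond the scatter) for 2-methylprop-1-en-1-yl in place of phenyl. It is beyond the scatter but modest, so an inhibitor in the series need not carry an aromatic ring at this position. No measurement at hand accounts for the rise.

Open, on these data alone, is whether a methyl group or an aminomethyl group here would stay as close to compound 3. Also open, as far as these compounds go, is whether the step would be similar with the 3-fluorophenyl group of compound 2.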